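The source may report more compounds than this note shows. Statements on the series, on what has been measured and on what is new or still open speak of the compounds shown alone.

For the measured compounds named here, in a functional assay on CFPAC-1 cells (Homo sapiens) for antiproliferative activity, read by MTT assay, with a stated time of 72 h (on this read-out lower numbers stand for stronger inhibition and higher numbers for weaker inhibition), two compounds that share one core have numbers so far. Compound 1 `CCCCCc1ccc(-c2cn(C[C@H](O)[C@H]3OC(=O)C(OCc4ccccc4)=C3OCc3ccccc3)nn2)cc1`, with a 4-pentylphenyl group, gives 9890 nM. Compound 2 `CCCCCCCCCCc1cn(C[C@H](O)[C@H]2OC(=O)C(OCc3ccccc3)=C2OCc2ccccc2)nn1`, with a decyl group in that place, gives 40300 nM, the higher of the two numbers and so the weaker inhibition.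

The next structure is compound 3 `Cc1ccc(-c2cn(C[C@H](O)[C@H]3OC(=O)C(OCc4ccccc4)=C3OCc3ccccc3)nn2)cc1`, in which 4-methylphenyl stands in place of decyl on an aromatic carbon: 4-methylphenyl in place of decyl on an aromatic carbon. Going by the values given here, only one measured step bears on this change, and it is a 4.1-fold higher number from compound 1 to compound 2 (0.61 log units; beyond the scatter). That step is modest but beyond the scatter, and it links a decyl group with a group that also holds a six-membered aromatic ring of carbon only. Compound 3 brings such a ring back, so a lower number than that of compound 2 is expected, in a step of similar or smaller size. Among the compounds with values here, no measured pair shows what methyl in place of pentyl does, so this expectation stays loose. The expected step is a 2.7-fold lower number from compound 2 to compound 3 (0.43 log units; beyond the scatter). For compound 3 the estimated value is 15000 nM, with an expected range of 6000 nM to 40000 nM.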

Compound 3, half-maximal inhibitory concentration: > 100000 nM
Compound 3: no number, only a limit (the forecaster's own chance of this, stated with the estimate: 5%); middle value at least 6.6-fold (0.82 log units) from the limit.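

Compound 3 gives a limit of the assay and not a number: the limit of > 100000 nM in this assay, at which 1 of the 3 values shown sits. The aromatic ring alone therefore does not lower the number, since 4-methylphenyl in place of decyl on the aromatic carbon brings an at least 2.4-fold higher number from compound 2 to compound 3 (0.39 log units; beyond the scatter), so a ring at this position is no advantage over the open chain when it carries only methyl. For the compounds shown here, what the earlier compounds could not show is how much the chain on that ring counts, and with the ring kept, methyl in place of pentyl brings an at least 10-fold higher number from compound 1 to compound 3 (1.00 log units; beyond the scatter), a step that changes only the length of that chain.

Since compound 3 has only a limit, the full size of both steps stays unknown, and the compounds shown do not tell whether the number falls gradually or abruptly between methyl and pentyl, as a propyl chain on the ring could show. They also leave open whether a chain longer than pentyl, such as octyl, would lower the number further, and what an amine or a carboxylic acid at the end of the chain would do.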